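Heteroaryl swap on the far ring: outlook for compound 4

This account rests on a few compounds, and the source may have more. Where it says the series, first, only, none or still open, it means among the compounds named here.

compound 1 `CCC(C)(C)Cc1c[nH]c(CCc2ccc(-c3cccc(C)n3)cc2)n1`: 106 nM
compound 2 `CCC(C)(C)Cc1c[nH]c(CCc2ccc(-c3cnccn3)cc2)n1`: 107 nM
compound 3 `c1ccc(-c2ccc(CCc3nc(CC4CCCC4)c[nH]3)cc2)nc1`: 103 nM

In a functional assay on HEK293 cells for agonist activity at Bombesin receptor subtype-3 (Mus musculus), read by luminescence and calcium flux, with a stated time of 10 min (on this read-out higher numbers stand for an effect only at larger amounts of compound and lower numbers for an effect already at smaller amounts), compound 2 gives 107 nM; the numbers for compound 1 (106 nM) and compound 3 (103 nM) sit within the scatter of it, so the three are not told apart by this read-out. Within the data shown here, one measured step bears on the change in hand: a 1.0-fold higher number from compound 1 to compound 2 (0.00 log units; within the scatter), which also exchanged the heteroaryl ring at the same aromatic carbon and left the read-out flat. Compound 4 `CCC(C)(C)Cc1c[nH]c(CCc2ccc(-c3cnsc3)cc2)n1` carries 1,2-thiazol-4-yl in place of pyrazin-2-yl on an aromatic carbon. Among the measured compounds shown here, with only that flat step as a guide, the change from compound 2 to compound 4 is expected to give no shift beyond the scatter, a 1.0-fold higher number from compound 2 to compound 4 (0.01 log units; within the scatter). Compound 4 is therefore estimated at 110 nM, with a range from 45 nM to 280 nM.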

Compound 4, half-maximal effective concentration: 119 nM
Beside the measured number, compound 4's estimate is 1.1-fold (0.03 log units) below it; the measured number falls inside the stated range.
By their numbers in this assay, from the lowest: compounds 3, 1, 2 and 4 (each within the scatter of the next).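

Placed on the aromatic carbon para to a large group, the 1,2-thiazol-4-yl ring gives a 1.1-fold higher number from compound 2 to compound 4 (0.05 log units; within the scatter) and a 1.1-fold higher number from compound 1 to compound 4 (0.05 log units; within the scatter) in this assay and so extends the flat picture from six-membered rings to a five-membered aromatic ring carrying sulfur. At this position, the read-out does not separate that ring from the rings of compound 1 and compound 2. Nothing on hand explains this flatness. Open, from the compounds shown here alone, is whether it persists with a non-aromatic group here, such as an amine or a carboxylic acid. Also open, going by these compounds, is whether the 1,2-thiazol-4-yl ring behaves alike on the core of compound 3.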